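Chloromethyl to iodomethyl on a second sugar-bearing core

The compounds below may be only part of what the source reports. "The series", "measured", "known", "first", "only" and "open" are said of these compounds alone.

Measured so far:
compound 1, `CCOC(=O)c1cc(CCl)nn1C1O[C@@H](COC(C)=O)[C@H](OC(C)=O)[C@@H](OC(C)=O)[C@@H]1OC(C)=O`, 40 ug/mL
compound 2, `CCOC(=O)c1cc(CI)nn1C1O[C@@H](COC(C)=O)[C@H](OC(C)=O)[C@@H](OC(C)=O)[C@@H]1OC(C)=O`, 2.5 ug/mL
compound 3, `CC(=O)OC[C@H]1O[C@@H](n2nc(CCl)cc2C(N)=O)[C@H](OC(C)=O)[C@@H]1OC(C)=O`, 26 ug/mL

All three were tested in a functional assay on HeLa cells (Homo sapiens); a lower number here means that less compound is needed, a higher number that more compound is needed for the effect. Compound 1 and compound 2 share one core and differ only by iodo in place of chloro on a saturated chain carbon bound to an aromatic carbon; this change gave a 16-fold lower number from compound 1 to compound 2 (1.20 log units; beyond the scatter). Compound 3 carries a different core; how the two cores differ is not broken down here. In this assay compound 3 gives a number close to that of compound 1, and the two lie within the usual scatter of each other, so no order between them can be read.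

Compound 4, `CC(=O)OC[C@H]1O[C@@H](n2nc(CI)cc2C(N)=O)[C@H](OC(C)=O)[C@@H]1OC(C)=O`, is not yet measured. It stands to compound 3 as compound 2 stands to compound 1: the difference is iodo in place of chloro on a saturated chain carbon bound to an aromatic carbon, at the same place, so it is the same change. Among the measured compounds shown here, because the one earlier example gave a 16-fold lower number from compound 1 to compound 2 (1.20 log units; beyond the scatter), a step of a similar size is expected for compound 4, although a single example is a thin basis. The expected step is a 10-fold lower number from compound 3 to compound 4 (1.02 log units; beyond the scatter), and the estimate for compound 4 in this assay is 2.5 ug/mL, between 1 ug/mL and 8 ug/mL.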

Compound 4, concentration for half-maximal effect: 1.5 ug/mL
For compound 4 the middle estimate is 1.7-fold (0.22 log units) above the measured one; the range from low to high includes it.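

In this assay, iodo in place of chloro on a saturated chain carbon bound to an aromatic carbon gave a 17-fold lower number from compound 3 to compound 4 (1.24 log units; beyond the scatter), and this step matches the earlier one on the other core: the same change on two cores in this assay, a 16-fold lower number (1.20 log units; beyond the scatter) from compound 1 to compound 2 and a 17-fold lower number (1.24 log units; beyond the scatter) from compound 3 to compound 4, 1.1-fold (0.03 log units) apart, within the scatter of two such steps. On these two cores, then, the change from chloromethyl to iodomethyl carries over with its size intact, so the step seen on the core of compound 1 was a fair guide for the core of compound 3. Among the compounds shown here, this rests on only one pair per core, so it does not show that the step would hold on any further core, and it does not explain why the iodo compounds need less compound for the effect.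

The compounds shown leave open whether bromo on the same carbon would give a step of similar size, or whether an amine there would keep the lower number. They also leave open whether the step would persist with a carboxylic acid on the core or with free hydroxyl groups on the sugar.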